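The source may report more compounds than this note shows. Statements on the series, on what has been measured and on what is new or still open speak of the compounds shown alone.

Three compounds have so far been measured in an assay for inhibition of 6-phosphofructo-2-kinase/fructose-2,6-bisphosphatase 3 (Homo sapiens), read by ADP-Glo, with a stated time of 2 h; on this read-out lower numbers stand for stronger inhibition and higher numbers for weaker inhibition:

compound 1, `CN1CCCC(NS(=O)(=O)c2ccccc2Nc2cc(-c3ccc4ccn(C)c4c3)c3nccnc3c2)C1`, giving 59 nM
compound 2, `CN1CCC(NS(=O)(=O)c2ccccc2Nc2cc(-c3ccc4ccn(C)c4c3)c3nccnc3c2)C1`, giving 33 nM
compound 3, `Cn1cc(CNC(=O)c2ccncc2Nc2cc(-c3ccc4ccn(C)c4c3)c3nccnc3c2)cn1`, giving 159 nM

Compound 3 stands at the highest number of the three, and its gaps to compound 1 and to compound 2 both go beyond the scatter. Compound 3 also differs from the other two in more than one place, so its position cannot be traced to any single change.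

Compound 4, `CC(=O)N1CC(CNC(=O)c2ccncc2Nc2cc(-c3ccc4ccn(C)c4c3)c3nccnc3c2)C1`, has not yet been measured. It differs from compound 3 in one place: 1-acetylazetidin-3-yl in place of 1-methyl-1H-pyrazol-4-yl on a saturated chain carbon bound to an amide-type nitrogen.

Within the data shown here, the only single-point step measured so far is a 1.8-fold lower number from compound 1 to compound 2 (0.25 log units; within the scatter), which concerns a different kind of ring swap in a different part of the molecule and stays within the scatter. Among the measured compounds shown here, no measured pair shows a change at the saturated chain carbon bound to the amide-type nitrogen, so nothing measured here bears directly on the step to compound 4. Without such a comparison, the plain expectation is a step no larger than the scatter in this assay, with the direction open. The estimated step is therefore a 1.1-fold higher number from compound 3 to compound 4 (0.03 log units; within the scatter). Compound 4 is expected to give about 170 nM, in a range from 60 nM to 500 nM.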

Compound 4, half-maximal inhibitory concentration: 137 nM
The estimate for compound 4 lay 1.2-fold (0.09 log units) above the measured number; the range from low to high includes it.
By their numbers in this assay, from the lowest: compounds 2 and 1 (each within the scatter of the next); then compounds 4 and 3 (each within the scatter of the next).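

In this assay, the step of a 1.2-fold lower number from compound 3 to compound 4 (0.06 log units; within the scatter) shows that the group on this saturated chain carbon bound to an amide-type nitrogen can be exchanged for a very different one without the number moving beyond the scatter. Among these compounds, a five-membered aromatic ring, 1-methyl-1H-pyrazol-4-yl, gives way to a four-membered non-aromatic ring bearing an acetyl group, 1-acetylazetidin-3-yl, which means that, for this pair, an aromatic ring at this place is not needed to keep the reading; the only earlier single-place step involved a ring on a sulfonamide nitrogen and could not show this. No measurement is available to explain why these two different groups read alike.

Both groups have a ring and carry no net charge, leaving open whether a group of another kind at the same place, such as an amine, a carboxylic acid or a longer open chain, would also leave the number within the scatter. Going by these compounds, it also remains open whether a plain phenyl ring would read like these two or shift the number in either direction.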